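The source may hold more compounds than are shown below. What is called first, only, known or untested is meant among the compounds shown, and "the series" means these compounds.

Measured so far:
Compound 1, `O=C(c1cc(Cl)ccc1-c1ncccn1)N1CC2(CC2)C[C@H]1CNc1ccc(C(F)(F)F)cn1`: 7.2
Compound 2, `Cc1ccc(-c2ncccn2)c(C(=O)N2CC3(CC3)C[C@H]2CNc2ccc(Cl)cn2)c1`: < 5 (a limit of the assay, not a number)
Compound 3, `N#Cc1ccc(-c2ncccn2)c(C(=O)N2CC3(CC3)C[C@H]2CNc2ccc(C(F)(F)F)cn2)c1`: 8.1

All three share one core and differ only in the group on the carbon ring and in the group on the pyridine. In a functional assay on HEK293 cells for antagonist activity at Orexin receptor type 2 (Homo sapiens), read by FLIPR and calcium flux (a lower number here means a less potent compound, a higher number a more potent compound, by a factor of ten per unit of this negative logarithm), compound 3 stands highest of the two numbers shown, with compound 1 as its nearest neighbour: a number 0.90 log units higher from compound 1 to compound 3 (beyond the scatter). For compound 2 the assay reports only a limit, (the limit of < 5 in this assay, at which 1 of the 3 values shown sits).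

Compound 4, `Cc1ccc(-c2ncccn2)c(C(=O)N2CC3(CC3)C[C@H]2CNc2ccc(C(F)(F)F)cn2)c1`, has not been measured. It differs from compound 3 in one place: methyl in place of cyano on an aromatic carbon. Within the data shown here, no measured step covers this exact swap. Among the measured compounds shown here, the one step on this ring, cyano in place of chloro, went up by a modest amount, so removing the cyano would be expected to give back that gain, and a methyl at this place is expected to fall somewhat further. Compound 2 also carries a methyl here and sits at the limit, though it differs from compound 4 in a second place as well. Compound 4 is therefore expected to come out at 6.2, between 5.1 and 7.3. That estimate means a step of a number 1.90 log units lower from compound 3 to compound 4 (beyond the scatter), clearly beyond the scatter and downward.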

Compound 4, negative logarithm of the antagonist equilibrium constant: 6.6
Compound 4: middle estimate off by 0.40 log units, on the low side; low and high end bracket the measured number.
By their numbers in this assay, from the lowest: compound 4; then compound 1; then compound 3. At a limit, below all of these: compound 2.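

With the rest of the molecule held the same, three groups can now be ranked on this aromatic carbon: nitrile over chloro over methyl. Methyl loses ground against chloro (a number 0.60 log units lower from compound 1 to compound 4 (beyond the scatter)) and far more against the nitrile (a number 1.50 log units lower from compound 3 to compound 4 (beyond the scatter)). The group on the pyridine matters too: with methyl kept on the carbon ring, trifluoromethyl in place of chloro gives a large rise (a number at least 1.60 log units higher from compound 2 to compound 4 (beyond the scatter)), although the value for compound 2 is a limit and not a number: (the limit of < 5 in this assay, at which 1 of the 4 values shown sits).

From the compounds shown here alone, what a methoxy group, an amine or a carboxylic acid would give on this aromatic carbon stays open, as does whether the same order of groups holds with chloro on the pyridine. The compounds shown also give no reason for the lead of the nitrile.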